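Acetyl on the amine nitrogen of compound 2

A few compounds are considered here, and "the series" means these few. Any claim that something is new, unique, unknown or untested is made for them only; others in the source may bear on it.

In a functional assay on MCF7 cells (Homo sapiens) for inhibition, read by MTT assay, with a stated time of 3 days (on this read-out higher numbers stand for weaker inhibition and lower numbers for stronger inhibition), compound 1 `CC[C@H](C)[C@@H](NCC(=O)NNC(=O)COc1ccc(-c2nc3ccccc3s2)cc1OC)C(=O)O` gives 1790 nM and compound 2 `COc1cc(-c2nc3ccccc3s2)ccc1OCC(=O)NNC(=O)CN[C@@H](CS)C(=O)O` gives 1230 nM, so the two stand level within the scatter. Compound 3 `COc1cc(-c2nc3ccccc3s2)ccc1OCC(=O)NNC(=O)CN(C(C)=O)[C@@H](CS)C(=O)O` keeps the core and side chain of compound 2 and carries acetyl in place of hydrogen on an amine nitrogen, that is, acetyl in place of hydrogen on an amine nitrogen. For the measured compounds named here, only one measured step bears on this nitrogen: a 1.5-fold lower number from compound 1 to compound 2 (0.16 log units; within the scatter), with 1-carboxy-2-sulfanylethyl in place of 1-carboxy-2-methylbutyl. Going by the values given here, that step is small, but it exchanges a different substituent, and no measured compound carries acetyl there, so it gives only weak guidance. No shift beyond the scatter is therefore expected in this assay, and no direction can be argued. The expected change is a 1.2-fold higher number from compound 2 to compound 3 (0.09 log units; within the scatter). For compound 3 the estimated value is 1500 nM, with an expected range of 500 nM to 4500 nM.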

Compound 3, half-maximal inhibitory concentration: 1750 nM
Beside the measured number, compound 3's estimate is 1.2-fold (0.07 log units) below it; the measured number falls inside the stated range.
By their numbers in this assay, from the lowest: compounds 2, 3 and 1 (each within the scatter of the next).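

In this assay, for the compounds shown here, acetyl in place of hydrogen on the amine nitrogen gives a 1.4-fold higher number from compound 2 to compound 3 (0.15 log units; within the scatter), the first reading of a change made directly at this nitrogen; losing that hydrogen and adding acetyl leaves the read-out level within the scatter. Against compound 1, acetyl(1-carboxy-2-sulfanylethyl)amino in place of (1-carboxy-2-methylbutyl)amino gives a 1.0-fold lower number from compound 1 to compound 3 (0.01 log units; within the scatter), so this exchange also leaves the number level. Nothing available explains why the read-out stays level at this nitrogen.

The compounds shown leave open whether a longer acyl chain, a benzoyl group or an aminoacetyl group on this nitrogen would also stay within the scatter of compound 2. They also leave open whether acetyl is tolerated equally when a methyl ester replaces the carboxylic acid.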